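Dichlorophenyl for Benzodioxinyl in a Raji Cytotoxicity Series

This account rests on a few compounds, and the source may have more. Where it says the series, first, only, none or still open, it means among the compounds named here.

Compound 1, `CCOC(=O)CCCCCOc1cccc(CN(C(=O)c2ccc(-c3cccc(NC(C)=O)c3)cc2)C(C)C)c1`, reaches only the limit > 26000 nM in an ADME assay on Raji cells (Homo sapiens) for cytotoxicity, read by CellTiter-Glo and resazurin assay, with a stated time of 72 h; on this read-out higher numbers stand for an effect only at larger amounts of compound and lower numbers for an effect already at smaller amounts.
Compound 2, `CCOC(=O)CCCCCOc1cccc(CN(C(=O)c2ccc(-c3ccc(C(C)=O)s3)cc2)C(C)C)c1`, reaches only the limit > 26000 nM in this assay.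
Compound 3, `CCOC(=O)CCCCCOc1cccc(CN(C(=O)c2ccc(-c3ccc4c(c3)OCCO4)cc2)C(C)C)c1`, reaches only the limit > 24400 nM in this assay.

Compound 3 stands at a limit of this assay, and the two other measured compounds also sit at limits: the limit of > 26000 nM in this assay, at which 2 of the 3 values shown sit, and (the limit of > 24400 nM in this assay, at which 1 of the 3 values shown sits). The steps a step that the two limits leave unreadable from compound 1 to compound 3 and a step that the two limits leave unreadable from compound 2 to compound 3 are therefore not readable in size, and the step that the two limits leave unreadable from compound 1 to compound 2 is no more readable. Every exchange of the group on the aromatic carbon so far has left the read-out at a limit.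

Compound 4, `CCOC(=O)CCCCCOc1cccc(CN(C(=O)c2ccc(-c3ccc(Cl)c(Cl)c3)cc2)C(C)C)c1`, differs from compound 3 by 3,4-dichlorophenyl in place of 2,3-dihydro-1,4-benzodioxin-6-yl on an aromatic carbon. The measured steps bear on this change only in showing that three different groups at this position all gave a limit, so no step beyond the scatter is expected in this assay in either direction. Compound 4 is expected to give about 26000 nM, in a range from 10000 nM to 60000 nM, and is most likely to be reported again as a limit. The estimated step that the limit leaves unreadable from compound 3 to compound 4 is expected to be negligible.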

Compound 4, half-maximal effective concentration: > 26000 nM
Compound 4: no number, only a limit; the forecaster's own chance of this, stated with the estimate: 75%; the middle value sits exactly at the limit.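

In this assay compound 4 reaches only the limit > 26000 nM, so its steps from compound 1, compound 2 and compound 3 cannot be read. The four compounds leave open how these groups on the aromatic carbon rank in this assay: none of them gives a number.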